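A few compounds are considered here, and "the series" means these few. Any claim that something is new, unique, unknown or untested is made for them only; others in the source may bear on it.

Compound 1 `Cc1ccc(C(=O)NO)cn1` is a hydroxamic acid carried on a six-membered aromatic ring with one nitrogen. In an assay on Sf9 cells for inhibition of protein deacetylase HDAC6 (Homo sapiens), read by fluorescence (a lower number here means a stronger inhibitor, a higher number a weaker inhibitor), compound 1 gives 70 nM. Two companions were measured alongside it: compound 2 `Nc1c(F)cc(C(=O)NO)cc1F` gives 112 nM in this assay, a number that lies within the scatter of that of compound 1, and compound 3 `CC(=O)Nc1ccc(C(=O)NO)cc1` gives 162 nM, a number that lies beyond the scatter above that of compound 1. Among the compounds with values here, no pair of these three differs in only one place, so no single step between measured compounds can be read off.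

Compound 4 `O=C(NO)c1cccnc1` differs from compound 1 by one change: hydrogen in place of methyl on an aromatic carbon. Within the data shown here, with no comparable step among the measured compounds, the size of this step rests on the change alone, a single carbon lost from the ring edge. A small rise in this assay, or none beyond the scatter, is expected; the step is estimated as a 1.4-fold higher number from compound 1 to compound 4 (0.15 log units; within the scatter). Compound 4 is therefore expected to give about 100 nM in this assay, within a range from 45 nM to 220 nM.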

Compound 4, half-maximal inhibitory concentration: 679 nM
Beside the measured number, compound 4's estimate is 6.8-fold (0.83 log units) below it, and the stated range ends below it.
By their numbers in this assay, from the lowest: compounds 1, 2 and 3 (each within the scatter of the next, the first and the last beyond it); then compound 4.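

The methyl on the aromatic carbon next to the ring nitrogen is far from a silent edge group in this assay: replacing it with hydrogen gives a 9.7-fold higher number from compound 1 to compound 4 (0.99 log units; beyond the scatter), although the change removes only one carbon. The earlier compounds shown here could not show this, since no two of them differ in only one place, and this pair now shows that this position has a marked bearing on the number in this assay. Nothing at hand bears on why a change of this size produces so large a step.

Going by these compounds, whether an ethyl, a methoxy or an amine at this same place would match the methyl, improve on it or fall back towards hydrogen remains open. On these data alone, the step also rests on this one pair, so whether the methyl counts for as much on any other core is unknown.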